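Isopropyl for hydroxyethyl, carried from one core to another

The compounds below may be only part of what the source reports. "The series", "measured", "known", "first", "only" and "open" are said of these compounds alone.

Three compounds have been run in an ADME assay on HeLa cells (Homo sapiens) for cytotoxicity, read by ATP content, with a stated time of 3 days; on this read-out lower numbers stand for higher toxicity in this test and higher numbers for lower toxicity in this test. Compound 1 `O=c1n(Cc2cc3cnccc3n2CCCCO)c2cnccc2n1C1CC1` carries a 4-hydroxybutyl chain on its core, and in this assay compound 1 reaches only the limit of the assay, > 100000 nM. Compound 2 `O=c1n(Cc2nc3cnccc3n2CCCCO)c2cnccc2n1C1CC1` carries the same chain on a core that differs from that of compound 1; how the two cores differ is not broken down here. In this assay compound 2 likewise stops at the limit, > 100000 nM. Compound 3 `CC(C)CCn1c(Cn2c(=O)n(C3CC3)c3ccncc32)nc2cnccc21` is compound 2 with isopropyl in place of 2-hydroxyethyl on a saturated chain carbon, two bonds along the chain from an aromatic nitrogen, and in this assay compound 3 also returns the limit, > 100000 nM. The step is therefore a step that the two limits leave unreadable from compound 2 to compound 3, and the only common ground of the three values is the limit of > 100000 nM in this assay, at which 3 of the 3 values shown sit.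

Compound 4 `CC(C)CCn1c(Cn2c(=O)n(C3CC3)c3ccncc32)cc2cnccc21` is still to be measured. It stands to compound 1 as compound 3 stands to compound 2: isopropyl in place of 2-hydroxyethyl on a saturated chain carbon, two bonds along the chain from an aromatic nitrogen, with the same place around the change, so it is the same change made on the core of compound 1. The account expects that the step from compound 1 to compound 4 will be a step that the limit leaves unreadable from compound 1 to compound 4, an expectation resting on a step that the two limits leave unreadable from compound 2 to compound 3 and on (the limit of > 100000 nM in this assay, at which 3 of the 3 values shown sit), which give no sign that this change reads out in this assay at all. Compound 4 is accordingly estimated at 150000 nM, most likely reported only as a limit, with the range 60000 nM to 400000 nM.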

Compound 4, half-maximal cytotoxic concentration: > 50000 nM
Compound 4: no number, only a limit; the forecaster's own chance of this, stated with the estimate: 85%; the middle value is on the limit's open side.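

In this assay compound 4 returns > 50000 nM, which is a limit and not a number. Isopropyl in place of 2-hydroxyethyl therefore gives a step that the two limits leave unreadable from compound 1 to compound 4, and no new step can be read. The compounds shown leave open whether this change moves the half-maximal cytotoxic concentration at all on either core, and at what concentration any of the four compounds would give an actual number.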